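This account rests on a few compounds, and the source may have more. Where it says the series, first, only, none or still open, it means among the compounds named here.

Compound 1 `CC[C@@H](CCn1cncn1)c1ccccc1` is the simplest of the shared core, and in an ADME assay on HEp-2 cells (Homo sapiens) for cytotoxicity, read by MTT assay, with a stated time of 3 days (a higher number here means that more compound is tolerated, a lower number that less compound is tolerated), compound 1 gives 89.9 ug/mL. Compound 2 `CC[C@@H](CCn1cncn1)c1ccc(Cl)cc1` differs from it by chloro in place of hydrogen on an aromatic carbon; in this assay compound 2 gives 55.1 ug/mL, a step of a 1.6-fold lower number from compound 1 to compound 2 (0.21 log units; within the scatter). Compound 3 `CCCC[C@H](CCn1cncn1)c1ccccc1` has a different core; the difference between the two cores is not broken down here. In this assay compound 3 gives 50.2 ug/mL. Compound 4 `CCCC[C@H](CCn1cncn1)c1ccc(Cl)cc1` is not yet measured; it differs from compound 3 by chloro in place of hydrogen on an aromatic carbon, the same change as from compound 1 to compound 2, at the same place. For compound 4 the expected step is a 1.5-fold lower number from compound 3 to compound 4 (0.17 log units; within the scatter), resting on the earlier step of a 1.6-fold lower number from compound 1 to compound 2 (0.21 log units; within the scatter), which stayed within the scatter. Compound 4 is estimated at 34 ug/mL. For compound 4 the expected range runs from 18 ug/mL to 70 ug/mL.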

Compound 4, half-maximal cytotoxic concentration: 20.2 ug/mL
For compound 4 the middle estimate is 1.7-fold (0.23 log units) above the measured one, within the range that was stated.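

In this assay, chloro in place of hydrogen on an aromatic carbon gives a 2.5-fold lower number from compound 3 to compound 4 (0.40 log units; beyond the scatter), and the two cores do not differ measurably in how they respond to this change: the same change on two cores in this assay, a 1.6-fold lower number (0.21 log units; within the scatter) from compound 1 to compound 2 and a 2.5-fold lower number (0.40 log units; beyond the scatter) from compound 3 to compound 4, 1.5-fold (0.18 log units) apart, within the scatter of two such steps. The change therefore carries across these two cores, with the number lower on both and the sizes of the two steps not separable. Within the data shown here, this rests on only two pairs, and the step on the core of compound 1 does not by itself exceed the scatter, so it shows neither that the change would carry to other cores nor why the number falls.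

The compounds shown leave open whether bromo or methoxy at the same place would act as chloro does. They also leave open whether the step would persist on a core with a longer chain.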